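Swapping the aryl group on the sulfonyl: a dichloro variant

The source may hold more compounds than are shown below. What is called first, only, known or untested is meant among the compounds shown, and "the series" means these compounds.

Measured so far:
Compound 1 `O=C(/C=C/c1cccc(NS(=O)(=O)c2ccccc2Cl)c1)c1nc2ccccc2[nH]1` gives 4790 nM in a functional assay on 143B cells (Homo sapiens) for antiproliferative activity, read by MTT assay, with a stated time of 48 h; on this read-out higher numbers stand for weaker inhibition and lower numbers for stronger inhibition.
Compound 2 `Cc1ccc(S(=O)(=O)Nc2cccc(/C=C/C(=O)c3nc4ccccc4[nH]3)c2)cc1` gives 3220 nM in this assay.

Among the compounds with values here, compound 2 holds the lowest of the two numbers, yet the only measured step, a 1.5-fold lower number from compound 1 to compound 2 (0.17 log units; within the scatter), falls within the scatter. Compound 3 `O=C(/C=C/c1cccc(NS(=O)(=O)c2cc(Cl)cc(Cl)c2)c1)c1nc2ccccc2[nH]1` carries the change (3,5-dichlorophenyl in place of 4-methylphenyl on a sulfonyl sulfur). That step touches the same aryl group on the sulfonyl sulfur as the measured one, which stayed within the scatter, so no step beyond the scatter is expected in this assay. Compound 3 is therefore estimated at 3500 nM, with a range from 1200 nM to 10000 nM, which means an expected 1.1-fold higher number from compound 2 to compound 3 (0.04 log units; within the scatter).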

Compound 3, half-maximal inhibitory concentration: 5950 nM
Estimate against measurement, compound 3: 1.7-fold (0.23 log units) below, and the stated range covers the measured number.
By their numbers in this assay, from the lowest: compounds 2, 1 and 3 (each within the scatter of the next).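

In this assay the 3,5-dichlorophenyl group brings a 1.8-fold higher number from compound 2 to compound 3 (0.27 log units; within the scatter) and also a 1.2-fold higher number from compound 1 to compound 3 (0.09 log units; within the scatter). A ring carrying two chlorine atoms therefore separates no more clearly from the other two aryl groups than they do from each other, and all three compounds remain within the scatter on the sulfonyl sulfur. Nothing available explains these small differences. Still open, going by these compounds, is whether something other than a substituted phenyl ring at this place, such as an amine or a longer carbon chain, would move the number beyond the scatter.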